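Inverting One Stereocentre After a Chain Extension

The compounds below may be only part of what the source reports. "The series", "measured", "known", "first", "only" and "open" are said of these compounds alone.

In a functional assay on HL-60 cells (Homo sapiens) for cytotoxicity (on this read-out lower numbers stand for stronger inhibition and higher numbers for weaker inhibition), compound 1 (`CCCO[C@H]1C=C(COC(C)=O)C(=O)[C@H](O)[C@H]1O`) gives 10100 nM and compound 2 (`CCCCCO[C@H]1C=C(COC(C)=O)C(=O)[C@H](O)[C@H]1O`) gives 3100 nM as the lower of the two numbers. Compound 3 (`CCCCCO[C@@H]1C=C(COC(C)=O)C(=O)[C@H](O)[C@H]1O`) keeps everything else: the two compounds have the same atoms and bonds and differ only in configuration as drawn: 1 of 3 stereo elements differ; a stereocentre at a saturated ring carbon is drawn S in compound 2 and R in compound 3 is the whole change. Among the compounds with values here, the only measured step, a 3.3-fold lower number from compound 1 to compound 2 (0.51 log units; beyond the scatter), alters the chain and not a configuration, so it says little here, and no measured pair shows what this inversion does. With so little to go on, a small rise is expected, and a 1.5-fold higher number from compound 2 to compound 3 (0.16 log units; within the scatter) is the estimated step. Compound 3 is expected at 4500 nM with an estimated range from 1500 nM to 13000 nM as its span.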

Compound 3, half-maximal inhibitory concentration: 2600 nM
Beside the measured number, compound 3's estimate is 1.7-fold (0.24 log units) above it; the range from low to high includes it.
By their numbers in this assay, from the lowest: compounds 3 and 2 (each within the scatter of the next); then compound 1.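

The comparison isolates a single feature: the fact that compounds 2 and 3 differ only in the configuration as drawn. Inverting the saturated ring carbon gives a 1.2-fold lower number from compound 2 to compound 3 (0.08 log units; within the scatter), so in this assay the S and R drawings cannot be told apart with this chain in place. Within the data shown here, the earlier step, a 3.3-fold lower number from compound 1 to compound 2 (0.51 log units; beyond the scatter), showed that the chain matters; this one gives the first reading on configuration at this carbon, and that reading shows no change beyond the scatter.

Going by these compounds, it remains open whether the same holds with the shorter chain of compound 1 or with a longer chain. On these data alone, it is also open whether an amine on this ring carbon would keep the number in this range.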